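This account rests on a few compounds, and the source may have more. Where it says the series, first, only, none or still open, it means among the compounds named here.

Measured so far:
compound 1 `Cc1ccc(NC(=O)c2cccc(C(F)(F)F)c2)cc1N1Cc2cnc(OC3CCNCC3)nc2N(C)C1=O` — > 10000 nM
compound 2 `Cc1ccc(NC(=O)c2cccc(C(F)(F)F)c2)cc1NC(=O)c1cnc(Nc2ccc(C)c([N+](=O)[O-])c2)nc1` — 8700 nM
compound 3 `CNc1nc(Nc2ccc(C)c([N+](=O)[O-])c2)ncc1C(=O)Nc1cc(NC(=O)c2ccccc2OC)ccc1C` — > 10000 nM

In an ADME assay on BaF3 cells (Mus musculus) for antiproliferative activity, read by CellTiter-Glo and CCK-8 assay, with a stated time of 72 h (on this read-out higher numbers stand for weaker inhibition of growth and lower numbers for stronger inhibition of growth), compound 3 reports only a limit, > 10000 nM, and not a number. Compound 3 thus sits at the limit of > 10000 nM in this assay, at which 2 of the 3 values shown sit, alongside compound 1, while compound 2 gives 8700 nM in this assay. Within the data shown here, no step between two measured compounds is available, so there is no measured step to lean on.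

Compound 4 `CNc1nc(Nc2ccc(C)c([N+](=O)[O-])c2)ncc1C(=O)Nc1cc(NC(=O)c2ccc3c(c2)OCCO3)ccc1C` differs from compound 3 only by 2,3-dihydro-1,4-benzodioxin-6-yl in place of 2-methoxyphenyl on a carbonyl carbon. With compound 3 already at the limit, the step from compound 3 to compound 4 is expected to be a step that the limit leaves unreadable from compound 3 to compound 4, none beyond the scatter. Compound 4 is therefore estimated at 15000 nM in this assay, with a range from 5000 nM to 50000 nM, most likely again reported only as a limit.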

Compound 4, concentration for 50% growth inhibition: > 10000 nM
Compound 4: a limit, no number; the forecaster's own chance of this, stated with the estimate: 80%; the middle value does not contradict the limit.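

Compound 3 and compound 4 both report only a limit, so no step can be read between them: the limit of > 10000 nM in this assay, at which 3 of the 4 values shown sit. The compounds shown leave open whether 2-methoxyphenyl and 2,3-dihydro-1,4-benzodioxin-6-yl differ at all in this assay.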